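The compounds below may be only part of what the source reports. "The series", "measured", "known", "first", "only" and "open" are said of these compounds alone.

Measured so far:
- Compound 1, `CC(C)=CC[C@H](OC(=O)C=C(C)C)C1=CC(=O)c2c(O)ccc(O)c2C1=O`: 770 nM
- Compound 2, `COc1ccc(O)c2c1C(=O)C=C(CCC=C(C)C)C2=O`: 5180 nM
- Compound 3, `COc1ccc(O)c2c1C(=O)C=C([C@H](CC=C(C)C)OC(C)=O)C2=O`: 660 nM

Among the compounds with values here, in an ADME assay on NIH3T3 cells (Mus musculus) for cytotoxicity, read by MTT assay, with a stated time of 48 h (on this read-out higher numbers stand for weaker inhibition and lower numbers for stronger inhibition), compound 3 gives the lowest number of the three, though compound 1 sits within the scatter of it; only compound 2 lies beyond the scatter, and that step, a 7.8-fold lower number from compound 2 to compound 3 (0.89 log units; beyond the scatter), is the single measured step in the set.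

Compound 4, `COc1ccc(O)c2c1C(=O)C=C([C@H](CC=C(C)C)OC(=O)C=C(C)C)C2=O`, differs from compound 3 by 2-methylprop-1-en-1-yl in place of methyl on a carbonyl carbon, so the change reads acetyl to (2-methylprop-1-en-1-yl)carbonyl. Within the data shown here, no measured pair isolates this change. Compound 1 carries the same ((2-methylprop-1-en-1-yl)carbonyl)oxy group on a different core and its value stands within the scatter of compound 3, so no step beyond the scatter is expected in this assay; the expected step is a 1.1-fold lower number from compound 3 to compound 4 (0.04 log units; within the scatter). Compound 4 is estimated at 600 nM, between 250 nM and 1500 nM.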

Compound 4, half-maximal inhibitory concentration: 4670 nM
Beside the measured number, compound 4's estimate is 7.8-fold (0.89 log units) below it; the whole stated range lies below it.
By their numbers in this assay, from the lowest: compounds 3 and 1 (each within the scatter of the next); then compounds 4 and 2 (each within the scatter of the next).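

In this assay, the gain from the acetoxy group on the shared core depends on the acyl group: 2-methylprop-1-en-1-yl in place of methyl on the carbonyl carbon gives (a 7.1-fold higher number from compound 3 to compound 4 (0.85 log units; beyond the scatter)). ((2-Methylprop-1-en-1-yl)carbonyl)oxy in place of hydrogen leaves the number within the scatter (a 1.1-fold lower number from compound 2 to compound 4 (0.05 log units; within the scatter)). The same ester behaves differently on the two cores, with methyl in place of hydrogen on an oxygen on an aromatic ring giving (a 6.1-fold higher number from compound 1 to compound 4 (0.78 log units; beyond the scatter)); nothing available gives a cause for these steps.

Going by these compounds, whether the higher number follows the added carbons or the double bond stays open. A saturated 3-methylbutanoyl group on the shared core would separate the two.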